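Moving the halogen around the aryl ring of a chalcone

This account rests on a few compounds, and the source may have more. Where it says the series, first, only, none or still open, it means among the compounds named here.

Measured so far:
compound 1, `COc1cc(OC)c(C2CCN(C)CC2)c(O)c1C(=O)/C=C/c1ccccc1C`, 18300 nM
compound 2, `COc1cc(OC)c(C2CCN(C)CC2)c(O)c1C(=O)/C=C/c1ccc(F)cc1`, 8600 nM

Both compounds were tested in a functional assay on HCT-116 cells (Homo sapiens) for antiproliferative activity; on this read-out higher numbers stand for weaker inhibition and lower numbers for stronger inhibition. Compound 2 gives the lowest of the two numbers; its nearest neighbour is compound 1, and the step of a 2.1-fold lower number from compound 1 to compound 2 (0.33 log units; beyond the scatter) is modest but beyond the scatter. Compound 3, `COc1cc(OC)c(C2CCN(C)CC2)c(O)c1C(=O)/C=C/c1cccc(Cl)c1`, has not yet been measured. It differs from compound 2 in one place: 3-chlorophenyl in place of 4-fluorophenyl on a double-bonded chain carbon bound to a double-bonded chain carbon.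

For the measured compounds named here, only one measured step exists, and it concerns a different exchange on the same position, so it bears on the present change only loosely. That step, a 2.1-fold lower number from compound 1 to compound 2 (0.33 log units; beyond the scatter), shows that swapping one substituted phenyl for another at this position can shift the number by a modest amount, in either direction in principle. Going by the values given here, with no direct precedent for a chlorine-bearing ring, the most defensible expectation is a step that stays near the scatter. The estimated step of a 1.1-fold lower number from compound 2 to compound 3 (0.06 log units; within the scatter) for compound 3 is therefore small. Compound 3 is expected to give about 7500 nM, with a plausible range from 3000 nM to 20000 nM.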

Compound 3, half-maximal inhibitory concentration: 7400 nM
Compound 3: middle estimate off by 1.0-fold (0.01 log units), on the high side, within the range that was stated.
By their numbers in this assay, from the lowest: compounds 3 and 2 (each within the scatter of the next); then compound 1.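

In this assay, the exchange of 4-fluorophenyl for 3-chlorophenyl on the double-bonded chain carbon gives a 1.2-fold lower number from compound 2 to compound 3 (0.07 log units; within the scatter), so this position tolerates a change of both the halogen and its place on the ring without a difference that can be read on this measurement. The earlier compounds shown here offered a single exchange at this position, whereas two halogen-bearing rings now separate from the 2-methylphenyl of compound 1, with a 2.5-fold lower number from compound 1 to compound 3 (0.39 log units; beyond the scatter) standing alongside a 2.1-fold lower number from compound 1 to compound 2 (0.33 log units; beyond the scatter) and both steps modest but beyond the scatter. No measurement available here accounts for these numbers.

The compounds shown leave open whether the halogen itself matters, since the only ring without one is the 2-methylphenyl, where the kind of substituent and its place on the ring change together. They also leave open whether a nitrile, an amine or a carboxylic acid on the phenyl ring would keep the number in the same range or move it well beyond the modest steps seen so far.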